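The source may report more compounds than this note shows. Statements on the series, on what has been measured and on what is new or still open speak of the compounds shown alone.

Three compounds built on a shared core have so far been examined in a functional assay on MCF7 cells (Homo sapiens) for cytotoxicity, read by MTT assay, with a stated time of 72 h; a higher number here means a weaker inhibitor, a lower number a stronger inhibitor. Compound 1 `O=C(Nc1ccc(Oc2ccnc3[nH]ccc23)cc1)c1nn(-c2ccc(Cl)cc2)ccc1=O` gives 10600 nM in this assay. Compound 2 `O=C(Nc1ccc(Oc2ccnc3[nH]ccc23)cc1)c1nn(-c2ccc(Br)cc2F)ccc1=O` gives 17900 nM, and the step of a 1.7-fold higher number from compound 1 to compound 2 (0.23 log units; within the scatter) remains within the scatter. Compound 3 `Cn1ccc2c(Oc3ccc(NC(=O)c4nn(-c5ccc(Cl)cc5)ccc4=O)cc3)ccnc21` reaches only the limit of this assay, > 60000 nM. This means the step of an at least 5.6-fold higher number from compound 1 to compound 3 (0.75 log units; beyond the scatter) is beyond the scatter, and compound 3 stands at the limit of > 60000 nM in this assay, at which 1 of the 3 values shown sits, so its true value is known only as lying past that bound.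

The next compound, compound 4 `Cn1ccc2c(Oc3ccc(NC(=O)c4nn(-c5ccccc5)ccc4=O)cc3)ccnc21`, differs from compound 3 by hydrogen in place of chloro on an aromatic carbon; read one bond further out, a 4-chlorophenyl becomes a phenyl, the change sitting para to a large group. Going by the values given here, no measured step repeats this change. The nearest comparison is the swap on the same ring recorded as a 1.7-fold higher number from compound 1 to compound 2 (0.23 log units; within the scatter), which stayed within the scatter, while the methylation recorded as an at least 5.6-fold higher number from compound 1 to compound 3 (0.75 log units; beyond the scatter) was the change that carried compound 3 to the limit. Compound 4 retains that methyl, so the expected step that the limit leaves unreadable from compound 3 to compound 4 is none beyond the scatter. Compound 4 is therefore estimated at 80000 nM, within a range of 30000 nM to 250000 nM, most likely again reported as a limit.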

Compound 4, half-maximal inhibitory concentration: 45200 nM
The estimate for compound 4 lay 1.8-fold (0.25 log units) above the measured number; the measured number falls inside the stated range.
By their numbers in this assay, from the lowest: compounds 1 and 2 (each within the scatter of the next); then compound 4. At a limit, above all of these: compound 3.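

In this assay, going by these compounds alone, compound 4 gives 45200 nM, the first reading for a ring with no halogen on it and the first change at this position, para to a large group, on the methylated core. The earlier swap on this ring, from 4-chlorophenyl to 4-bromo-2-fluorophenyl, kept a halogen and kept hydrogen on the aromatic nitrogen. Compound 3 stands at a limit and not at a number: the limit of > 60000 nM in this assay, at which 1 of the 4 values shown sits.

The change from 4-chlorophenyl to phenyl therefore reads only as an at least 1.3-fold lower number from compound 3 to compound 4 (0.12 log units; that floor lies within the scatter), which gives a floor and no true size, so these two compounds do not establish a real difference between chloro and hydrogen at this position.

As far as these compounds go, it remains open whether the same change would matter on the core of compound 1, where hydrogen rather than methyl sits on the aromatic nitrogen and both partners could give numbers. From the compounds shown here alone, it is also open how this position would read with a methoxy group, an amine or a nitrile in place of the chloro.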